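A Bromophenyl in Place of Dimethylphenyl: Expected Cytotoxicity

The source may hold more compounds than are shown below. What is called first, only, known or untested is meant among the compounds shown, and "the series" means these compounds.

Three compounds have been measured in a functional assay on DU-145 cells (Homo sapiens) for cytotoxicity, read by MTT assay, with a stated time of 48 h; on this read-out lower numbers stand for stronger inhibition and higher numbers for weaker inhibition:
compound 1 `CCOC(=O)c1c(-c2c(Cl)c3ccccc3oc2=O)nn(-c2ccccc2)c1C(=O)OCC`, 48000 nM
compound 2 `CCOC(=O)c1c(-c2c(Cl)c3ccccc3oc2=O)nn(-c2ccc(OC)cc2)c1C(=O)OCC`, 25000 nM
compound 3 `CCOC(=O)c1c(-c2cc3ccccc3oc2=O)nn(-c2ccc(C)c(C)c2)c1C(=O)OCC`, 40000 nM

Compound 3 gives the second highest of the three numbers; its nearest neighbour is compound 1, which lies within the scatter of it, and the furthest is compound 2, also within the scatter. So the three measured compounds are, in effect, indistinguishable in this assay.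

The new compound is compound 4 `CCOC(=O)c1c(-c2cc3ccccc3oc2=O)nn(-c2ccc(Br)cc2)c1C(=O)OCC`. It differs from compound 3 in one place: 4-bromophenyl in place of 3,4-dimethylphenyl on an aromatic nitrogen. For the measured compounds named here, only one measured step bears on a change of the ring on this nitrogen, the step of a 1.9-fold lower number from compound 1 to compound 2 (0.28 log units; within the scatter), where a methoxy was added to the phenyl on that same nitrogen. That step stayed within the scatter, and compound 1 and compound 2 carry a chlorine on the shared core that compound 3 and compound 4 lack, so it is only a loose guide. With nothing pointing in either direction, a step of about a 1.1-fold lower number from compound 3 to compound 4 (0.02 log units; within the scatter) is expected, that is, none beyond the scatter. Compound 4 is therefore estimated at 38000 nM, within a range from 18000 nM to 80000 nM.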

Compound 4, half-maximal inhibitory concentration: 61000 nM
Beside the measured number, compound 4's estimate is 1.6-fold (0.21 log units) below it; low and high end bracket the measured number.
By their numbers in this assay, from the lowest: compounds 2, 3, 1 and 4 (each within the scatter of the next, the first and the last beyond it).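

In this assay, putting 4-bromophenyl in place of 3,4-dimethylphenyl on the aromatic nitrogen gives a 1.5-fold higher number from compound 3 to compound 4 (0.18 log units; within the scatter) and so does not separate the two compounds. For the compounds shown here, this is the first measured change to this ring on the shared core without the chlorine, and it shows that a ring with one bromine and a ring with two methyl groups cannot be told apart here, even though the ring itself and its place stay the same while its substituents differ in both kind and number. No measurement is available that could explain this result or show what either group does in the cells.

As far as these compounds go, whether a very different substituent on this ring, such as an amine or a carboxylic acid, would move the number beyond the scatter remains open, as does the effect of a longer chain in place of the bromine. From the compounds shown here alone, it is also open whether the same exchange of rings would give a similar result on the core that carries the chlorine, where compound 1 and compound 2 were measured.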